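The source may report more compounds than this note shows. Statements on the series, on what has been measured and on what is new or still open speak of the compounds shown alone.

In a physicochemical assay for solubility, read by LC-MS, in phosphate buffer, with a stated time of 24 h, at pH 6.8 (on this read-out lower numbers stand for lower solubility and higher numbers for higher solubility), compound 2, `C[C@@H](c1ccc(NC(=O)N2CC(c3cncc(N)c3)C2)cc1)N1Cc2ccccc2C1=O`, gives 35000 nM. This is the higher of the two numbers available, and the gap to compound 1, `C[C@H](NC(=O)c1cccc(F)c1)c1ccc(NC(=O)N2CC(c3cccnc3)C2)cc1`, which gives 11000 nM, lies beyond the usual scatter. Compound 3, `C[C@H](NC(=O)c1cccc(F)c1)c1ccc(NC(=O)N2CC(c3cncc(N)c3)C2)cc1`, has not yet been measured. It differs from compound 2 by one change on a saturated chain carbon bound to an aromatic carbon and a saturated chain carbon: a group of 10 heavy atoms (7 carbon, 1 nitrogen, 1 oxygen, 1 fluorine; one six-membered aromatic ring of carbon only) in place of a group of 10 heavy atoms (8 carbon, 1 nitrogen, 1 oxygen; one five-membered non-aromatic ring with 1 hetero atom, one six-membered aromatic ring of carbon only), on a saturated chain carbon bound to an aromatic carbon and a saturated chain carbon. The entering ((3-fluorophenyl)carbonyl)amino group is also present in compound 1, although that compound differs from compound 3 elsewhere in its structure. For the measured compounds named here, with only that lower value of 11000 nM for compound 1 as a guide, a modest fall in this assay is expected, one that would probably stay within the scatter. The expected step is a 1.8-fold lower number from compound 2 to compound 3 (0.24 log units; within the scatter). Compound 3 is expected to give about 20000 nM, with an estimated range of 8000 nM to 45000 nM.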

Compound 3, solubility: 17000 nM
Compound 3: the middle estimate sits 1.2-fold (0.07 log units) above what was measured, within the range that was stated.
By their numbers in this assay, from the lowest: compounds 1 and 3 (each within the scatter of the next); then compound 2.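

In this assay, for the compounds shown here, placing ((3-fluorophenyl)carbonyl)amino on the saturated chain carbon bound to an aromatic carbon and a saturated chain carbon gives a 2.1-fold lower number from compound 2 to compound 3 (0.31 log units; beyond the scatter) with the rest of the structure unchanged, the first reading of this position on its own, and the step is modest. Amino in place of hydrogen on an aromatic carbon gives a 1.5-fold higher number from compound 1 to compound 3 (0.19 log units; within the scatter) in the same assay, so this second change cannot be told apart from repeat measurement. Nothing in the available data accounts for either step.

On these data alone, it remains open how a smaller group on that chain carbon, such as acetylamino, would read in this assay. As far as these compounds go, whether a methylamino or hydroxy group on that aromatic carbon would separate from hydrogen also remains open.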